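This account rests on a few compounds, and the source may have more. Where it says the series, first, only, none or still open, it means among the compounds named here.

Compound 1, `Cc1ccc(-c2[nH]c3ccccc3c2C2=C(Br)C(=O)C(Br)=C(Br)C2=O)cc1`, gives 21.6 ug/mL in a functional assay on MDA-MB-231 cells (Homo sapiens) for antiproliferative activity, read by CCK-8 assay, with a stated time of 48 h (on this read-out higher numbers stand for weaker inhibition and lower numbers for stronger inhibition), the highest of the three numbers measured in this series. The two other measured compounds, compound 2, `Cc1[nH]c2ccccc2c1C1=C(Cl)C(=O)C(c2c(-c3ccccc3)[nH]c3ccccc23)=C(Cl)C1=O`, with 4.46 ug/mL in this assay, and compound 3, `COc1ccc2[nH]c(C)c(C3=C(Cl)C(=O)C(c4c(-c5ccc(C)cc5)[nH]c5ccccc45)=C(Cl)C3=O)c2c1`, with 4.15 ug/mL, both sit well beyond the scatter from compound 1, and their own two values lie within the scatter of each other.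

Compound 4, `COc1ccc2[nH]c(C)c(C3=C(Br)C(=O)C(c4c(-c5ccc(C)cc5)[nH]c5ccccc45)=C(Br)C3=O)c2c1`, has not yet been measured. It differs from compound 1 by 5-methoxy-2-methyl-1H-indol-3-yl in place of bromo on a double-bonded ring carbon. Among the compounds with values here, no single step between two measured compounds isolates this change, so the comparison rests on what the values show: compound 3 shares the two indolyl groups with compound 4 and carries chloro in place of bromo, and its number stands far below that of compound 1.

Compound 4 is therefore expected to move in the direction of stronger inhibition, with a step from compound 1 estimated as a 4.3-fold lower number from compound 1 to compound 4 (0.64 log units; beyond the scatter). The value expected for compound 4 in this assay is 5 ug/mL, within a range from 2 ug/mL to 12 ug/mL.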

Compound 4, half-maximal inhibitory concentration: 3.99 ug/mL
Compound 4: the middle estimate sits 1.3-fold (0.10 log units) above what was measured, within the range that was stated.
By their numbers in this assay, from the lowest: compounds 4, 3 and 2 (each within the scatter of the next); then compound 1.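

Replacing bromo with 5-methoxy-2-methyl-1H-indol-3-yl on this double-bonded ring carbon gives the series its first single change that can be read directly in this assay (a 5.4-fold lower number from compound 1 to compound 4 (0.73 log units; beyond the scatter)). The position therefore accepts a far larger group, with two aromatic rings in place of one halogen atom, and the number falls beyond the scatter rather than rising. No measurement shown here bears on why the number falls.

This single step cannot show whether the whole indolyl group is needed, or which of its parts, the methoxy, the methyl or the ring system, accounts for the change. It also leaves open whether an amine or a longer alkyl chain on the same ring carbon would lower the number to a similar extent.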